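Working notes: from compound 2 to compound 3

The compounds below may be only part of what the source reports. "The series", "measured", "known", "first", "only" and "open" are said of these compounds alone.

Compound 1 `CC(=O)OCCn1cc(CNC(=O)c2cn(Cc3ccccc3)nn2)nn1` gives 28000 nM in a functional assay on B16 cells (Mus musculus) for cytotoxicity, read by MTT assay, with a stated time of 48 h; on this read-out lower numbers stand for stronger inhibition and higher numbers for weaker inhibition. Compound 2 `CCOC(=O)Cn1cc(CNC(=O)c2cn(CC(=O)OCc3ccccc3)nn2)nn1` stands only at a limit, > 100000 nM, in this assay. Compound 3 `CC(=O)OCCn1cc(CNC(=O)c2cn(CC(=O)OCc3ccccc3)nn2)nn1` has the same atoms as compound 2, joined differently: acetoxymethyl in place of ethoxycarbonyl on a saturated chain carbon bound to an aromatic nitrogen. Among the measured compounds shown here, no measured step isolates this change. With compound 1 at 28000 nM, a small step toward lower numbers in this assay is expected, not clearly beyond the scatter. The expected step runs an at least 1.6-fold lower number from compound 2 to compound 3 (0.22 log units; that floor lies within the scatter). Compound 3 is estimated at 60000 nM, with an expected range of 22000 nM to 150000 nM.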

Compound 3, half-maximal inhibitory concentration: > 100000 nM
Compound 3: a limit, no number; the forecaster's own chance of this, stated with the estimate: 45%; at least 1.6-fold (0.22 log units) between middle value and limit.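

In this assay, compound 3 sits at a limit, and the exchange of ethoxycarbonyl for acetoxymethyl cannot be read because compound 2 is also limited: the limit of > 100000 nM in this assay, at which 2 of the 3 values shown sit.

Among the compounds shown here, the first readable step is an at least 3.5-fold higher number from compound 1 to compound 3 (0.55 log units; beyond the scatter), with benzyloxycarbonyl in place of phenyl on a saturated chain carbon bound to an aromatic nitrogen and the 2-acetoxyethyl chain held constant.

From the compounds shown here alone, whether the ethoxycarbonyl to acetoxymethyl exchange has any effect with phenyl in place remains open. So does the effect in this assay of a carboxylic acid in place of benzyloxycarbonyl, or of an amine at the end of the 2-acetoxyethyl chain.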